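Sulfonyl substituent change within the urea series

A few compounds are considered here, and "the series" means these few. Any claim that something is new, unique, unknown or untested is made for them only; others in the source may bear on it.

In an assay on isolated protein for inhibition of Nicotinamide phosphoribosyltransferase (Homo sapiens), read by mass spectrometry, with stated times of 15 min and 30 min (on this read-out lower numbers stand for stronger inhibition and higher numbers for weaker inhibition), compound 1 `O=C(NCc1ccc(S(=O)(=O)c2ccccc2)cc1)N1Cc2cccnc2C1` gives 60 nM. Compound 2 `O=C(NCc1ccc(S(=O)(=O)C2CCOCC2)cc1)N1Cc2ccncc2C1` gives 26 nM, the lowest of the two numbers in this assay; compound 1 sits higher by a gap beyond the usual scatter. Compound 3 `O=C(NCc1ccc(S(=O)(=O)N2CC3(CCOCC3)C2)cc1)N1Cc2ccncc2C1` has not been measured in this assay. It differs from compound 2 at the sulfonyl sulfur: a group of 9 heavy atoms (7 carbon, 1 nitrogen, 1 oxygen; one four-membered non-aromatic ring with 1 hetero atom, one six-membered non-aromatic ring with 1 hetero atom) in place of a group of 6 heavy atoms (5 carbon, 1 oxygen; one six-membered non-aromatic ring with 1 hetero atom), on a sulfonyl sulfur. Among the measured compounds shown here, no measured pair tracks this change, so the expected step of a 1.5-fold higher number from compound 2 to compound 3 (0.19 log units; within the scatter) is held small and, if anything, toward a weaker number. Compound 3 is estimated at 40 nM, within a range of 12 nM to 130 nM.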

Compound 3, half-maximal inhibitory concentration: 20 nM
Beside the measured number, compound 3's estimate is 2.0-fold (0.30 log units) above it; the range from low to high includes it.
By their numbers in this assay, from the lowest: compounds 3 and 2 (each within the scatter of the next); then compound 1.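

The sulfonyl sulfur, with its other neighbour an aromatic carbon, accepts the two-ring group of 9 heavy atoms in place of oxan-4-yl: in this assay the swap gives a 1.3-fold lower number from compound 2 to compound 3 (0.11 log units; within the scatter). Among the compounds shown here, this is the first single-place step, and it shows that the added four-membered non-aromatic ring and the added heavy atoms leave the read-out within the scatter. No available evidence bears on this result. From the compounds shown here alone, how a carboxylic acid or a longer chain on the sulfonyl sulfur would read remains open. Compound 1 differs from compound 2 in more than one place, so its sulfonyl substituent cannot be compared on its own.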